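Replacing 4-cyanophenyl with 2-fluorophenyl

A few compounds are considered here, and "the series" means these few. Any claim that something is new, unique, unknown or untested is made for them only; others in the source may bear on it.

Of the compounds shown here, three built on a shared core have been measured in an ADME assay on L02 cells (Homo sapiens) for cytotoxicity, read by MTT assay, with a stated time of 24 h; a lower number here means a stronger inhibitor, a higher number a weaker inhibitor. Compound 1 (`O=C1/C(=C/c2cccc([N+](=O)[O-])c2)CN(S(=O)(=O)c2ccc(F)cc2)C/C1=C\c1cccc([N+](=O)[O-])c1`) gives 15500 nM, compound 2 (`N#Cc1ccc(/C=C2\CN(S(=O)(=O)c3ccc(F)cc3)C/C(=C\c3ccc(C#N)cc3)C2=O)cc1`) gives 18900 nM and compound 3 (`CC(=O)Nc1ccc(S(=O)(=O)N2C/C(=C\c3ccc(C#N)cc3)C(=O)/C(=C/c3ccc(C#N)cc3)C2)cc1`) gives 14000 nM. Compound 3 therefore stands within the scatter of both other compounds, and the three numbers cannot be ranked.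

Compound 4 (`CC(=O)Nc1ccc(S(=O)(=O)N2C/C(=C\c3ccc(C#N)cc3)C(=O)/C(=C/c3ccccc3F)C2)cc1`) departs from compound 3 in one place: 2-fluorophenyl in place of 4-cyanophenyl on a double-bonded chain carbon bound to a double-bonded ring carbon. This puts 2-fluorophenyl in place of 4-cyanophenyl on a double-bonded chain carbon bound to a double-bonded ring carbon.

Among the measured compounds shown here, no measured step makes this replacement. For the measured compounds named here, the only step available, a 1.4-fold lower number from compound 2 to compound 3 (0.13 log units; within the scatter), is acetamido in place of fluoro on an aromatic carbon, a change elsewhere in the molecule, and it stays within the scatter. Compound 1 at 15500 nM and compound 2 at 18900 nM also lie within the scatter of each other, although their aromatic groups differ. On this limited evidence, the expected change is a 1.1-fold higher number from compound 3 to compound 4 (0.03 log units; within the scatter), which means no step beyond the scatter and no firm direction. For compound 4 the estimated value in this assay is 15000 nM, with an expected range of 8000 nM to 28000 nM.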

Compound 4, half-maximal inhibitory concentration: 14400 nM
The estimate for compound 4 lay 1.0-fold (0.02 log units) above the measured number; the range from low to high includes it.
By their numbers in this assay, from the lowest: compounds 3, 4, 1 and 2 (each within the scatter of the next).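

In this assay, this is the first single-place change shown on a double-bonded chain carbon bound to a double-bonded ring carbon, and it gives a 1.0-fold higher number from compound 3 to compound 4 (0.01 log units; within the scatter). The earlier pair with different aromatic groups, compound 1 and compound 2, differs on both arms, so it could not isolate one arm; here only one 4-cyanophenyl is exchanged, and the other arm and the acetamido-bearing sulfonyl side are the same in both compounds. The exchange takes away a nitrile and its 1 hydrogen-bond acceptor and brings in a fluorine-bearing ring with 0 hydrogen-bond acceptors, yet the two numbers cannot be told apart, and no measurement given here accounts for this result.

Going by these compounds, this single exchange speaks only for 2-fluorophenyl in the setting of compound 3, so it remains open whether replacing the remaining 4-cyanophenyl of compound 4 would give a number outside the scatter. On these data alone, it also remains open whether a ring carrying an amine or a carboxylic acid at this place would give a step beyond the scatter, which none of the four compounds shows.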